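Fluoro in Place of Trifluoromethyl at the Same Position

The compounds below may be only part of what the source reports. "The series", "measured", "known", "first", "only" and "open" are said of these compounds alone.

Measured compounds:
compound 1, `COc1cc(OC)c2c(=O)cc(/C=C/c3ccc(OCC4CC4)cc3)oc2c1`, gives 20900 nM in a functional assay on A549 cells (Homo sapiens) for antiproliferative activity, read by MTT assay, with a stated time of 12 h; a lower number here means a stronger inhibitor, a higher number a weaker inhibitor
compound 2, `COc1cc(OC)c2c(=O)cc(/C=C/c3ccc(C(F)(F)F)cc3)oc2c1`, gives > 40000 nM in this assay

Compound 2 stands at the edge of what this assay reports: its value is a limit, not a number, and (the limit of > 40000 nM in this assay, at which 1 of the 2 values shown sits). Within the data shown here, the one measured step, an at least 1.9-fold higher number from compound 1 to compound 2 (0.28 log units; that floor lies within the scatter), thus rests on a floor and cannot be sized beyond what is given.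

Compound 3, `COc1cc(OC)c2c(=O)cc(/C=C/c3ccc(F)cc3)oc2c1`, differs from compound 2 in one place: fluoro in place of trifluoromethyl on an aromatic carbon. Among the measured compounds shown here, the only step that bears on it is the one from compound 1 to compound 2, which touched the same aromatic carbon and whose size is given as a floor within the scatter. From that step alone no direction can be drawn for the change to fluoro, so no step beyond the scatter is expected in this assay.

Compound 3 is therefore estimated at 30000 nM, within a range from 10000 nM to 90000 nM. The expected step is an at least 1.3-fold lower number from compound 2 to compound 3 (0.12 log units; that floor lies within the scatter), and a further limit rather than a number remains a real possibility.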

Compound 3, half-maximal inhibitory concentration: 18600 nM
The estimate for compound 3 lay 1.6-fold (0.21 log units) above the measured number, and the stated range covers the measured number.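

Among these compounds, at this aromatic carbon, para to a large group, the change from trifluoromethyl to fluoro gives the first step in this assay that lies beyond the scatter: an at least 2.1-fold lower number from compound 2 to compound 3 (0.33 log units; beyond the scatter). Compound 2 gives > 40000 nM, which is a limit and not a number, so this step has a floor and its full size stays unknown: the limit of > 40000 nM in this assay, at which 1 of the 3 values shown sits. Fluoro and cyclopropylmethoxy, by contrast, cannot be told apart at this carbon, with a 1.1-fold lower number from compound 1 to compound 3 (0.05 log units; within the scatter), so two quite different groups here give readable values and, of the three groups shown, only trifluoromethyl reaches the limit.

Going by these compounds, whether an amine, a carboxylic acid or a longer alkoxy chain at this carbon would move the number beyond the scatter from those of compound 1 and compound 3 remains open, and so does whether any group here can bring the number far below theirs. The compounds shown also give no reason for the step away from trifluoromethyl, and they do not tell whether it would hold on another core or in another cell line.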